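Series notes: piperidine end group on the amine chain

A few compounds are considered here, and "the series" means these few. Any claim that something is new, unique, unknown or untested is made for them only; others in the source may bear on it.

Three compounds of the shared core have been run in an assay on isolated protein for antagonist activity at advanced glycosylation end product-specific receptor (Homo sapiens), read by ELISA, with a stated time of 60 min, tested at 10 uM; a lower number here means less inhibition, a higher number more inhibition at the concentration tested (going by the name of the read-out). Compound 1 `CCCCc1sc(-c2ccc(OCCCN(C)C)cc2)nc1-c1ccc(Oc2ccc(Cl)cc2)cc1` gives 46.2%. Compound 3 `CCCCc1sc(Nc2ccc(OCCCN(CC)CC)cc2)nc1-c1ccc(Oc2ccc(Cl)cc2)cc1` gives 60.9%, and compound 2 `CCCCc1sc(-c2ccc(Oc3ccc(Cl)cc3)cc2)nc1-c1ccc(OCc2ccccc2)cc1` gives 2.4%. Among these three numbers compound 1 stands second highest; its nearest neighbour is compound 3, whose value lies higher by a margin beyond the usual scatter, and its furthest is compound 2, whose value lies lower by a much larger margin, also beyond the scatter. Within the data shown here, no pair of measured compounds differs in a single place, so the move to compound 4 has no direct precedent within the set.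

Compound 4 `CCCCc1sc(-c2ccc(OCCCN3CCCCC3)cc2)nc1-c1ccc(Oc2ccc(Cl)cc2)cc1` differs from compound 1 in one place: piperidin-1-yl in place of dimethylamino on a saturated chain carbon, three bonds along the chain from an oxygen on an aromatic ring. The chain ending in an amine is kept; only the open amine end becomes a ring.

In this assay the step from compound 1 to compound 4 is expected to be small, no larger than the scatter, with any lean upward: a number 3.8 percentage points higher from compound 1 to compound 4 (within the scatter). The estimate for compound 4 is 50%, within a range of 30% to 70%. Support comes from compound 3, which also carries an amine-ended chain and gives 60.9%, whereas compound 2, lacking such a chain, gives 2.4%.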

Compound 4, a percentage reported as inhibition, at one concentration (the size of the read-out at that concentration, not a potency): 59.2%
For compound 4 the middle estimate is 9.2 percentage points below the measured one, and the stated range covers the measured number.
By their numbers in this assay, from the lowest: compound 2; then compound 1; then compounds 4 and 3 (each within the scatter of the next).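

In this assay, among these compounds, piperidin-1-yl in place of dimethylamino, on a saturated chain carbon three bonds along the chain from an oxygen on an aromatic ring, gives a number 13 percentage points higher from compound 1 to compound 4 (beyond the scatter) and provides the first single-place step. This position therefore accepts a ring at the amine end with no loss of inhibition at the concentration tested, and the choice of end group shifts the number by a modest amount. Nothing measured here accounts for the step.

On these data alone, whether the ring itself or simply the larger end group carries the step remains open. Pyrrolidin-1-yl or morpholin-4-yl on the same chain would help separate the two, and a longer chain ending in piperidin-1-yl would test the chain length.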